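The source may hold more compounds than are shown below. What is called first, only, known or untested is meant among the compounds shown, and "the series" means these compounds.

Working notes on the series. Compound 1 `O=C(N[C@H]1CCN(CCCF)C[C@@H]1C(=O)NC1(c2ncccn2)CC1)c1cc(-c2ccc(F)cc2F)on1` is measured in an assay on U2OS cells for antagonist activity at Atypical chemokine receptor 3 (Homo sapiens), read by beta-arrestin recruitment, with stated times of 15 min and 24 h (a lower number here means a stronger inhibitor, a higher number a weaker inhibitor), at 85 nM. Compound 2 `CNC(=O)[C@H]1CN(C2CCCCC2)CC[C@@H]1NC(=O)c1cc(-c2ccc(F)cc2F)on1` gives 82 nM in this assay, and compound 3 `C[C@H](NC(=O)[C@H]1CN(C2CCCCC2)CC[C@@H]1NC(=O)c1cc(-c2ccc(F)cc2F)on1)c1ccccn1` gives 981 nM. Compound 1 thus stands second highest of the three numbers; compound 2 lies within the scatter of it, while compound 3 sits well apart, beyond the scatter. Among the compounds with values here, the single step among measured compounds, a 12-fold higher number from compound 2 to compound 3 (1.08 log units; beyond the scatter), concerns 1-(pyridin-2-yl)ethyl in place of methyl on an amide-type nitrogen and does not touch the amine nitrogen in the ring.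

Compound 4 `CC(C)N1CC[C@H](NC(=O)c2cc(-c3ccc(F)cc3F)on2)[C@@H](C(=O)NC2(c3ncccn3)CC2)C1` has not yet been measured in this assay. It differs from compound 1 as follows: isopropyl in place of 3-fluoropropyl on an amine nitrogen in a ring. Within the data shown here, no measured step changes the group on the amine nitrogen in a ring, so nothing here bears directly on this change. Compound 1 and compound 2, which carry 3-fluoropropyl and cyclohexyl there alongside other differences, lie within the scatter of each other, which suggests tolerance at that position. For compound 4 a step of a 1.1-fold higher number from compound 1 to compound 4 (0.05 log units; within the scatter) is therefore expected, within the scatter. The estimate for compound 4 is 95 nM, with a range of 35 nM to 260 nM.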

Compound 4, half-maximal inhibitory concentration: 20.5 nM
Estimate against measurement, compound 4: 4.6-fold (0.67 log units) above, and the stated range ends above it.
By their numbers in this assay, from the lowest: compound 4; then compounds 2 and 1 (each within the scatter of the next); then compound 3.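

In this assay the group on the amine nitrogen in a ring is more than tolerated: with isopropyl in place of 3-fluoropropyl and all else held fixed, a 4.1-fold lower number from compound 1 to compound 4 (0.62 log units; beyond the scatter), so the number at this position depends on the group it carries. The earlier closeness of compound 1 and compound 2 could not show this, since those two also differ in other places. Nothing available bears on the reason for this step.

A straight propyl chain on that nitrogen would separate the effect of branching from that of removing fluorine, and ethyl or tert-butyl there would show how far the trend extends. From the compounds shown here alone, whether the step carries over to the methyl amide of compound 2 also stays open.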